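The source may report more compounds than this note shows. Statements on the series, on what has been measured and on what is new or still open speak of the compounds shown alone.

In a functional assay on a cell-free system (Platelet, plasma, Homo sapiens) for inhibition, read by turbidimetry, with a stated time of 3 min (on this read-out lower numbers stand for stronger inhibition and higher numbers for weaker inhibition), compound 1 `COc1ccc(-n2nc(C(=O)Nc3ccncc3)cc2-c2ccc(Cl)cc2)nn1` gives 110 nM, the lower of the two exact numbers available. Compound 2 `CS(=O)(=O)c1ccc(-n2nc(C(=O)N3CCCCC3)cc2-c2ccc(Cl)cc2)nn1` gives a far weaker 19600 nM. For compound 3 `COc1ccc(-n2nc(C(=O)N3CCCCC3)cc2C)nn1`, > 10000 nM is a limit and not an exact number. Compound 4 `COc1ccc(-n2nc(CCC(=O)N3CCOCC3)cc2-c2ccc(Cl)cc2)nn1` has yet to be measured in this assay. It keeps the core of compound 1 but swaps one group on an aromatic carbon: 2-((morpholin-4-yl)carbonyl)ethyl in place of (pyridin-4-yl)carbamoyl on an aromatic carbon. Compound 4 thus loses the (pyridin-4-yl)carbamoyl group, which compound 2 also lacks at 19600 nM, so weaker inhibition, beyond the scatter, is expected. The expected size of the change is a 14-fold higher number from compound 1 to compound 4 (1.13 log units; beyond the scatter). For compound 4 the estimate is 1500 nM, with an expected range from 200 nM to 10000 nM.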

Compound 4, half-maximal inhibitory concentration: 1080 nM
Beside the measured number, compound 4's estimate is 1.4-fold (0.14 log units) above it; measured number inside the range.
By their numbers in this assay, from the lowest: compound 1; then compound 4; then compound 2.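

Putting 2-((morpholin-4-yl)carbonyl)ethyl in place of (pyridin-4-yl)carbamoyl on this aromatic carbon gives a 9.8-fold higher number from compound 1 to compound 4 (0.99 log units; beyond the scatter) and so weakens inhibition without abolishing it. This first one-place comparison shows that the (pyridin-4-yl)carbamoyl group, with its amide hydrogen, helps at this position but is not essential for measurable inhibition. Nothing shown here explains the size of this step.

Still open, going by these compounds, is which part of the change matters: the amide hydrogen, the aromatic ring or the chain. A carboxylic acid or a longer chain on this carbon would test this further.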